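The compounds below may be only part of what the source reports. "The series", "measured", "known", "first", "only" and "open" are said of these compounds alone.

Measured in a functional assay on A549 cells (Homo sapiens) for antiproliferative activity, read by MTT assay, with a stated time of 24 h; a higher number here means a weaker inhibitor, a lower number a stronger inhibitor:
compound 1 `COc1cc(-c2cc(C(=O)/C=C/c3ccccc3)nc3cc(-c4ccccc4)nn23)cc(OC)c1OC`, 18000 nM
compound 2 `COc1ccc(-c2cc(/C=C/C(=O)c3ccc(C)cc3)nc3cc(-c4ccccc4)nn23)cc1OC`, 17200 nM
compound 3 `COc1cc(-c2cc(/C=C/C(=O)c3ccc(C)cc3)nc3cc(-c4ccccc4)nn23)cc(OC)c1OC`, 19400 nM

Compound 2 cannot be told apart from compound 1 or compound 3 in this assay; its number lies within the scatter of both. Compound 4 `COc1ccc(-c2cc(/C=C/C(=O)c3ccc(Cl)cc3)nc3cc(-c4ccccc4)nn23)cc1OC` differs from compound 2 by chloro in place of methyl on an aromatic carbon. For the measured compounds named here, no measured step exchanges a methyl for a chloro or alters the 4-methylphenyl group at all. The two recorded steps, a 1.1-fold higher number from compound 1 to compound 3 (0.03 log units; within the scatter) and a 1.1-fold higher number from compound 2 to compound 3 (0.05 log units; within the scatter), touch other parts of the shared core and both stay within the scatter, so the series has yet to show any movement in this assay. For compound 4 the expected step is accordingly a 1.0-fold lower number from compound 2 to compound 4 (0.01 log units; within the scatter), nothing beyond the scatter. Compound 4 is estimated at 17000 nM in this assay, in the range 8000 nM to 36000 nM.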

Compound 4, half-maximal inhibitory concentration: 15400 nM
The estimate for compound 4 lay 1.1-fold (0.04 log units) above the measured number; low and high end bracket the measured number.
By their numbers in this assay, from the lowest: compounds 4, 2, 1 and 3 (each within the scatter of the next).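

In this assay, for the compounds shown here, chloro in place of methyl on the aromatic carbon para to a large group gives a 1.1-fold lower number from compound 2 to compound 4 (0.05 log units; within the scatter), the first measured exchange at this position. The 4-methylphenyl and 4-chlorophenyl forms cannot be told apart here, so this position, like the other places varied on the shared core, has shown no movement beyond the scatter. Nothing available bears on the reason for this.

Still open, going by these compounds, is whether an amine or a carboxylic acid at this position would give a step beyond the scatter. Also open, on these data alone, is whether the same exchange reads alike on the core of compound 3.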